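The compounds below may be only part of what the source reports. "The series", "measured", "known", "first", "only" and "open" are said of these compounds alone.

- compound 1 `COc1cc(C2=NOC(c3cc(OC)c(OC)c(OC)c3)C2)ccc1O`: 2600 nM
- compound 2 `COc1ccc(C2=NOC(COc3ccc(-c4nnnn4-c4cc(OC)c(OC)c(OC)c4)cc3N)C2)cc1N`: 2080 nM

In a functional assay on A549 cells (Homo sapiens) for cytotoxicity, read by MTT assay, with a stated time of 48 h (a higher number here means a weaker inhibitor, a lower number a stronger inhibitor), compound 2 gives 2080 nM and compound 1 gives 2600 nM. These two numbers lie within the usual scatter of each other, so compound 2 cannot be ranked apart from compound 1. Compound 3 `COc1cc(C2=NOC(COc3ccc(-c4nnnn4-c4cc(OC)c(OC)c(OC)c4)cc3N)C2)cc(OC)c1OC` has 3,4,5-trimethoxyphenyl in place of 3-amino-4-methoxyphenyl on a carbon with a double bond to nitrogen. For the measured compounds named here, no measured pair shows this change on its own, so the estimate is loose. The expected 1.1-fold higher number from compound 2 to compound 3 (0.04 log units; within the scatter) is small, no larger than the scatter. For compound 3 the estimated value is 2300 nM, with an expected range from 800 nM to 6500 nM.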

Compound 3, half-maximal inhibitory concentration: 2060 nM
For compound 3 the middle estimate is 1.1-fold (0.05 log units) above the measured one, and the stated range covers the measured number.
By their numbers in this assay, from the lowest: compounds 3, 2 and 1 (each within the scatter of the next).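

In this assay putting 3,4,5-trimethoxyphenyl in place of 3-amino-4-methoxyphenyl on a carbon with a double bond to nitrogen gives a 1.0-fold lower number from compound 2 to compound 3 (0.00 log units; within the scatter) and so compound 3 cannot be ranked apart from compound 2. For the compounds shown here, at this position, then, the number holds through a swap that removes the amine and adds methoxy groups, the first direct reading of this change. Nothing available explains this result. As far as these compounds go, whether an unsubstituted phenyl or a carboxylic acid on this ring would shift the number remains open.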